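The compounds below may be only part of what the source reports. "The series", "measured", "known", "first", "only" and "open" are said of these compounds alone.

Notes on the series: in an ADME assay on microsomes from liver (Homo sapiens) for metabolic stability, with a stated time of 30 min (a higher number here means that more of the compound is left, a lower number that less of the compound is left), compound 1 (`CC(C)(C)[C@@H](CO)n1cc(C(=O)O)c(=O)c2cc(Cc3cccc(Cl)c3F)c(O)nc21`) gives 87%, the only number so far. Compound 2 (`COc1nc2c(cc1Nc1ccc(Cl)c(F)c1)c(=O)c(C(=O)O)cn2[C@H](CO)C(C)C`) stands at "not determined" (no result reported), and compound 3 (`COc1nc2c(cc1Nc1ccc(F)cc1)c(=O)c(C(=O)O)cn2[C@H](CO)C(C)C`) at "not determined" (no result reported), so compound 3 has no single number and no place in any ranking. Compound 4 (`COc1nc2c(cc1NCc1ccc(F)cc1)c(=O)c(C(=O)O)cn2[C@H](CO)C(C)C`) awaits measurement. The structural change is 4-fluorobenzyl in place of 4-fluorophenyl on a nitrogen on an aromatic ring. For the measured compounds named here, no measured step exists to size this change, so in this assay no step beyond the scatter is expected, in either direction. Going by the values given here, the sole anchor is compound 1 at 87%, a different compound, which justifies a wide range and a cautious middle. Compound 4 is expected at 70%, with an estimated range of 42% to 92%.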

Compound 4, percent of the compound remaining: 87%
Compound 4: middle estimate off by 17 percentage points, on the low side; the measured number falls inside the stated range.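

For the compounds shown here, no step from compound 3 to compound 4 can be read in this assay. The compounds shown leave open how 4-fluorobenzyl in place of 4-fluorophenyl shifts the read-out in this assay. No evidence on this result is available.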